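Phenyl to Pentyl on the Amide Nitrogen: Compound 4

This account rests on a few compounds, and the source may have more. Where it says the series, first, only, none or still open, it means among the compounds named here.

Compound 1 `C=CC1=C(C(=O)NCCCCC)C(c2ccc(Cl)c(Cl)c2)OC1` in a functional assay on QGY7701 cells (Homo sapiens) for cytotoxicity, read by MTT assay, with a stated time of 24 h (on this read-out higher numbers stand for weaker inhibition and lower numbers for stronger inhibition), gives only a limit, > 100000 nM. Compound 2 `C=CC1=C(C(=O)Nc2ccccc2)C(c2ccc(Cl)c(Cl)c2)OC1` likewise gives only a limit in this assay, > 100000 nM. Within the data shown here, compound 3 `C=CC1=C(C(=O)Nc2ccccc2)C(c2ccc(F)cc2)OC1` is the one compound with a number, giving 46700 nM in this assay.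

Compound 4 `C=CC1=C(C(=O)NCCCCC)C(c2ccc(F)cc2)OC1` is not yet measured. It differs from compound 3 by pentyl in place of phenyl on an amide-type nitrogen. The same change, in the same place, is already seen from compound 2 to compound 1, (pentyl in place of phenyl on an amide-type nitrogen), where the step in this assay is a step that the two limits leave unreadable from compound 2 to compound 1, because both values sit at the limit of > 100000 nM in this assay, at which 2 of the 3 values shown sit. The two cores differ by 4-fluorophenyl in place of 3,4-dichlorophenyl on a saturated ring carbon, a step of an at least 2.1-fold lower number from compound 2 to compound 3 (0.33 log units; beyond the scatter) in this assay.

With the earlier step unreadable, the expected step from compound 3 to compound 4 is a 1.3-fold higher number from compound 3 to compound 4 (0.11 log units; within the scatter), resting on compound 3 at 46700 nM. Compound 4 is estimated at 60000 nM, between 20000 nM and 200000 nM.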

Compound 4, half-maximal inhibitory concentration: > 100000 nM
Compound 4 was reported as a limit; the forecaster's own chance of this, stated with the estimate: 40%; middle value at least 1.6-fold (0.22 log units) from the limit.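

In this assay, from the compounds shown here alone, pentyl in place of phenyl on the amide-type nitrogen gives an at least 2.1-fold higher number from compound 3 to compound 4 (0.33 log units; beyond the scatter), and the full size of this step stays unknown since compound 4 gives only a limit. The same change in the core of compound 2 cannot be read, because compound 1 and compound 2 stand at one limit: the limit of > 100000 nM in this assay, at which 3 of the 4 values shown sit. The weaker inhibition with pentyl is therefore shown in one core only, and these compounds do not show whether it carries over to another core.

Going by these compounds, it remains open whether a benzyl or cyclohexyl group on the amide-type nitrogen would give a measurable number with 4-fluorophenyl on the saturated ring carbon. On these data alone, the effect of a shorter chain, such as propyl, or of a pentyl chain ending in an amine also remains open.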